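Methoxy in place of fluoro on the phenoxy ring

A few compounds are considered here, and "the series" means these few. Any claim that something is new, unique, unknown or untested is made for them only; others in the source may bear on it.

Compound 3 `Cc1ccc(-c2n[nH]c(NC(=O)COc3ccccc3F)n2)cc1` is one of three compounds on a shared core that have been tested in an assay on CHO cells for inhibition of adenosine receptor A1 (Homo sapiens), read by scintillation counting, with a stated time of 60 min, tested at 10 uM; a higher number here means more inhibition at the concentration tested (going by the name of the read-out), a lower number less inhibition. In that assay compound 3 gives 2%. Compound 2 `O=C(COc1ccccc1)Nc1nc(-c2ccc(F)cc2)n[nH]1` gives 2%, level with compound 3 at the digits reported and within the scatter, while compound 1 `O=C(COc1ccccc1)Nc1nc(-c2ccccc2)n[nH]1` gives 20%, so compound 3 sits well below compound 1. Going by the values given here, the only single-point step measured so far is a number 18 percentage points lower from compound 1 to compound 2 (beyond the scatter), and that step concerns the other aromatic ring, not the one altered here.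

Compound 4 `COc1ccccc1OCC(=O)Nc1nc(-c2ccc(C)cc2)n[nH]1` differs from compound 3 by methoxy in place of fluoro on an aromatic carbon. Among the compounds with values here, no measured step bears on this change: fluoro appears at this place only in compound 3, and the comparison of compound 2 with compound 3 involves a second difference on the other ring, so it cannot be read as a single step. The measured numbers of compound 2 and compound 3 do show that adding fluoro there alongside the methyl left the read-out unchanged. With nothing in the data pointing one way or the other, the step is expected to lie within the scatter, a number 2 percentage points higher from compound 3 to compound 4 (within the scatter). Compound 4 is therefore estimated at 4%, with a range from -8% to 18%.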

Compound 4, a percentage reported as inhibition, at one concentration (the size of the read-out at that concentration, not a potency): 8%
Beside the measured number, compound 4's estimate is 4 percentage points below it; low and high end bracket the measured number.
By their numbers in this assay, from the lowest: compounds 2, 3 and 4 (each within the scatter of the next); then compound 1.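

Going by these compounds alone, the change from 2-fluorophenyl to 2-methoxyphenyl is the first single-place change read at this aromatic carbon, ortho to a large group, and in this assay it amounts to a number 6 percentage points higher from compound 3 to compound 4 (within the scatter) and no more. Within the data shown here, the earlier compounds gave a single-place step only on the other aromatic ring, so this is the first sign that a swap of fluoro for methoxy at this place leaves the number without a change beyond the scatter, even though the entering group has 2 heavy atoms and 1 hydrogen-bond acceptor where fluoro has 1 heavy atom and no acceptor. Nothing available explains this outcome or ties it to any property of either group.

Among these compounds, whether an amine, a carboxylic acid or a longer chain such as ethoxy at this place would move the read-out beyond the scatter remains open, since fluoro and methoxy are the only two groups compared here. Also open, from the compounds shown here alone, is whether the same swap would read alike on the shared core with hydrogen or fluoro in place of the methyl on the other ring.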